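Swapping the amine-bearing ring on the aromatic oxygen

A few compounds are considered here, and "the series" means these few. Any claim that something is new, unique, unknown or untested is made for them only; others in the source may bear on it.

Measured so far:
compound 1 `CCOc1nc(-c2ccc(NS(=O)(=O)c3cc(Cl)ccc3F)cc2)nc2[nH]nc(C)c12` gives 183 nM
compound 2 `Cc1n[nH]c2nc(-c3ccc(NS(=O)(=O)c4cc(Cl)ccc4F)cc3)nc(OCCC(=O)N(C)C)c12` gives 438 nM
compound 3 `Cc1n[nH]c2nc(-c3ccc(NS(=O)(=O)c4cc(Cl)ccc4F)cc3)nc(OCC3CN(C(C)C)C3)c12` gives 1 nM

All three were tested in an assay for inhibition of serine/threonine-protein kinase Sgk1 (Homo sapiens), with stated times of 30 min and 60 min, in the presence of a further agent that is not named here; on this read-out lower numbers stand for stronger inhibition and higher numbers for weaker inhibition. On the numbers shown, compound 3 stands lowest of the three, well apart from compound 1 and further still from compound 2.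

Compound 4 `Cc1n[nH]c2nc(-c3ccc(NS(=O)(=O)c4cc(Cl)ccc4F)cc3)nc(OC3CC(C)(C)N(C)C(C)(C)C3)c12` differs from compound 3 by the change (1,2,2,6,6-pentamethylpiperidin-4-yl in place of (1-isopropylazetidin-3-yl)methyl on an oxygen on an aromatic ring). Among the compounds with values here, the steps that bear on this are a 180-fold lower number from compound 1 to compound 3 (2.26 log units; beyond the scatter) and a 440-fold lower number from compound 2 to compound 3 (2.64 log units; beyond the scatter); both show that placing a saturated nitrogen-containing ring on this chain, in place of a methyl or a dimethylcarbamoyl-bearing chain, accompanied a large drop in the number. Compound 4 keeps a saturated ring with one nitrogen on the same oxygen, though the ring is larger, attached directly rather than through a chain carbon, and carries five methyl groups. Within the data shown here, no measured pair shows the effect of such a swap, so the expectation is a modest rise, a 4.0-fold higher number from compound 3 to compound 4 (0.60 log units; beyond the scatter). Compound 4 is therefore estimated at 4 nM, within a range of 0.7 nM to 25 nM.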

Compound 4, half-maximal inhibitory concentration: 3 nM
Estimate against measurement, compound 4: 1.3-fold (0.12 log units) above; low and high end bracket the measured number.
By their numbers in this assay, from the lowest: compound 3; then compound 4; then compound 1; then compound 2.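

In this assay, the change from (1-isopropylazetidin-3-yl)methoxy to (1,2,2,6,6-pentamethylpiperidin-4-yl)oxy is only a modest step, a 3.0-fold higher number from compound 3 to compound 4 (0.48 log units; beyond the scatter), while the large steps of a 150-fold lower number from compound 2 to compound 4 (2.16 log units; beyond the scatter) and a 61-fold lower number from compound 1 to compound 4 (1.79 log units; beyond the scatter) show how much of the gain over the open chains remains. The low numbers at this oxygen are therefore not tied to the four-membered ring: a six-membered ring with one nitrogen, attached directly rather than through a chain carbon, also gives them. This single swap changes ring size, attachment and methyl groups together, so their separate contributions cannot be told apart. A plain piperidin-4-yl without the methyl groups, or a cyclohexyl ring with no nitrogen, would be needed to show whether the methyl groups or the ring nitrogen matter. Nothing available here accounts for these differences.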